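The source may report more compounds than this note shows. Statements on the series, on what has been measured and on what is new or still open speak of the compounds shown alone.

In a functional assay on MDA-MB-436 cells (Homo sapiens) for antiproliferative activity, read by MTT assay, with a stated time of 48 h (on this read-out higher numbers stand for weaker inhibition and lower numbers for stronger inhibition), compound 1 `C=CS(=O)(=O)N1CCN(c2ncnc3sc(-c4ccc(N5CCN(C)CC5)cc4)cc23)CC1`, with vinyl on a sulfonyl sulfur, gives 8760 nM. Compound 2 `CCS(=O)(=O)N1CCN(c2ncnc3sc(-c4ccc(N5CCN(C)CC5)cc4)cc23)CC1`, with ethyl in that place, gives 10600 nM. Among the compounds with values here, compound 2 therefore stands within the scatter of compound 1, the only other measured compound, and the pair defines a single step, a 1.2-fold higher number from compound 1 to compound 2 (0.08 log units; within the scatter). Compound 3 `CN1CCN(c2ccc(-c3cc4c(N5CCN(S(=O)(=O)N6CCCCC6)CC5)ncnc4s3)cc2)CC1` keeps the shared core and changes the same place: piperidin-1-yl in place of ethyl on a sulfonyl sulfur. In words, this is piperidin-1-yl in place of ethyl on a sulfonyl sulfur. Within the data shown here, the one measured change on this sulfur, a 1.2-fold higher number from compound 1 to compound 2 (0.08 log units; within the scatter), lies within the scatter, but it offers only limited guidance. Neither of its groups contains a ring. No step beyond the scatter is expected in this assay, in either direction, and the range is kept wide. The estimated step is a 1.2-fold lower number from compound 2 to compound 3 (0.07 log units; within the scatter). Compound 3 is estimated at 9000 nM, with an expected range from 3500 nM to 23000 nM.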

Compound 3, half-maximal inhibitory concentration: 7570 nM
The estimate for compound 3 lay 1.2-fold (0.08 log units) above the measured number; the measured number falls inside the stated range.
By their numbers in this assay, from the lowest: compounds 3, 1 and 2 (each within the scatter of the next).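

In this assay, piperidin-1-yl brings the first ring to this sulfonyl sulfur, with 6 heavy atoms where ethyl has 2, yet the result is a 1.4-fold lower number from compound 2 to compound 3 (0.15 log units; within the scatter). Against vinyl, the same group gives a 1.2-fold lower number from compound 1 to compound 3 (0.06 log units; within the scatter). Within the data shown here, the earlier pair compared only two groups without a ring, whereas these steps show that a six-membered non-aromatic ring with 1 hetero atom can also stand on this sulfur with no step beyond the scatter, so the three groups cannot be told apart here. Nothing available explains why the numbers stay so close. Still open, going by these compounds, is whether a phenyl or morpholin-4-yl group on this sulfur, or a carboxylic acid at the end of a longer chain there, would move the number beyond the scatter in either direction.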